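Cytotoxicity of a Shared Core with Varied Aryl Substituent

This account rests on a few compounds, and the source may have more. Where it says the series, first, only, none or still open, it means among the compounds named here.

Measured compounds:
- compound 1, `COc1cccc(Oc2ccc3c(NCCCNCc4cccc(OC)c4O)ccnc3c2)c1`, 5300 nM
- compound 2, `COc1cccc(CNCCCNc2ccnc3cc(CC(C)C)ccc23)c1O`, 2920 nM

Both compounds were tested in an ADME assay on HepG2 cells (Homo sapiens) for cytotoxicity, read by luminescence, CellTiter-Glo and ATP content, with a stated time of 72 h; on this read-out higher numbers stand for an effect only at larger amounts of compound and lower numbers for an effect already at smaller amounts. Compound 2 gives 2920 nM, the lowest of the two numbers, yet the gap to compound 1 at 5300 nM is within the usual scatter, so the two numbers are not distinguished. Going by the values given here, the one step available, a 1.8-fold lower number from compound 1 to compound 2 (0.26 log units; within the scatter), put isobutyl in place of 3-methoxyphenoxy on an aromatic carbon and produced no change beyond the scatter.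

Compound 3, `COc1ccccc1Oc1ccc2c(NCCCNCc3cccc(OC)c3O)ccnc2c1`, has not been measured. Its difference from compound 2 is 2-methoxyphenoxy in place of isobutyl on an aromatic carbon. Among the compounds with values here, this is close to the reverse of the one step above, with the methoxy group moved on the phenoxy ring. Because a 1.8-fold lower number from compound 1 to compound 2 (0.26 log units; within the scatter) was within the scatter, no step beyond the scatter is expected in this assay in either direction.

Compound 3 is therefore estimated at 4500 nM, with a range from 1800 nM to 11000 nM. The expected step is a 1.5-fold higher number from compound 2 to compound 3 (0.19 log units; within the scatter), essentially flat.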

Compound 3, half-maximal effective concentration: 11200 nM
For compound 3 the middle estimate is 2.5-fold (0.40 log units) below the measured one; measured number above the stated range.
By their numbers in this assay, from the lowest: compounds 2 and 1 (each within the scatter of the next); then compound 3.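

In this assay, this aromatic carbon of the shared core turns out to respond to what it carries, which the earlier pair could not show: putting 2-methoxyphenoxy in place of isobutyl gives a 3.8-fold higher number from compound 2 to compound 3 (0.58 log units; beyond the scatter). Where the methoxy group sits on the phenoxy ring also counts: 2-methoxyphenyl in place of 3-methoxyphenyl on the oxygen gives a 2.1-fold higher number from compound 1 to compound 3 (0.32 log units; beyond the scatter), and a phenoxy group at this place does not by itself set the number, as compound 1 carries one and stays within the scatter of compound 2. Both steps are modest, yet they leave compound 3 with the highest number of the three, meaning that it takes the largest amount of compound for the effect to appear on these cells.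

The compounds shown leave open how a plain phenoxy group without a methoxy group, an amine or a carboxylic acid on this same aromatic carbon would compare with these three. No further measurement given here offers an explanation for the rise in the number at compound 3.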